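Trading a hydroxy for a chloro on the outer ring

The source may hold more compounds than are shown below. What is called first, only, known or untested is meant among the compounds shown, and "the series" means these compounds.

Of the compounds shown here, three sharing one core have been tested in an ADME assay on Raji cells (Homo sapiens) for cytotoxicity, read by CellTiter-Glo and resazurin assay, with a stated time of 72 h; a higher number here means that more compound is needed for the effect, a lower number that less compound is needed. Compound 1 `CC(C)N(Cc1cccc(OCCCCCC(=O)O)c1)C(=O)c1ccccc1` carries hydrogen where the others carry a second ring. In this assay compound 1 gives > 26000 nM, which is a limit of the assay and not a measured number. Compound 2 `COc1cc(OC)cc(-c2ccc(C(=O)N(Cc3cccc(OCCCCCC(=O)O)c3)C(C)C)cc2)c1` adds a 3,5-dimethoxyphenyl. In this assay compound 2 gives > 26000 nM, again a limit. Compound 3 `CC(C)N(Cc1cccc(OCCCCCC(=O)O)c1)C(=O)c1ccc(-c2cccc(O)c2)cc1` adds a 3-hydroxyphenyl instead. In this assay compound 3 gives > 26000 nM, also a limit. So compound 3 stands with the other two at the limit of > 26000 nM in this assay, at which 3 of the 3 values shown sit, and the steps a step that the two limits leave unreadable from compound 1 to compound 2, a step that the two limits leave unreadable from compound 1 to compound 3 and a step that the two limits leave unreadable from compound 2 to compound 3 cannot be sized, because all three values are limits.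

Compound 4 `CC(C)N(Cc1cccc(OCCCCCC(=O)O)c1)C(=O)c1ccc(-c2cccc(Cl)c2)cc1` differs from compound 3 by chloro in place of hydroxy on an aromatic carbon, so the 3-hydroxyphenyl becomes a 3-chlorophenyl. Among the measured compounds shown here, no measured step tells how such a change acts here; the only guide is that every compound so far sits at the limit. Compound 4 is therefore expected to give about 30000 nM, within 8000 nM to 100000 nM, most likely reported again as a limit. The step that the limit leaves unreadable from compound 3 to compound 4 is thus expected to be small or not readable.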

Compound 4, half-maximal effective concentration: > 21900 nM
Compound 4: a limit, no number (the forecaster's own chance of this, stated with the estimate: 70%); the middle value lies beyond the limit too.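

In this assay compound 4 gives > 21900 nM, which is a limit and not a measured number. Its steps from compound 1, compound 2 and compound 3 therefore cannot be read. The compounds shown leave open whether any of them has a measurable effect in this assay, and at what concentration.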